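Bromo to Trifluoromethyl on a Fused Imide Scaffold

The compounds below may be only part of what the source reports. "The series", "measured", "known", "first", "only" and "open" are said of these compounds alone.

Compound 1 `COc1ccc2c(c1)[nH]c1c2c2c(c3c4cccc5c4n(c13)CC(CO)C5)C(=O)NC2=O` gives 490 ug/mL in a physicochemical assay for solubility; on this read-out lower numbers stand for lower solubility and higher numbers for higher solubility. Compound 2 `O=C1NC(=O)c2c1c1c3ccc(Br)cc3[nH]c1c1c2c2cccc3c2n1CC(CO)C3` gives 830 ug/mL in this assay, and the step of a 1.7-fold higher number from compound 1 to compound 2 (0.23 log units; within the scatter) is the only one measured so far. Compound 2 therefore stands with the higher of the two numbers, but its separation from compound 1 lies within the scatter. Compound 3 `O=C1NC(=O)c2c1c1c3ccc(C(F)(F)F)cc3[nH]c1c1c2c2cccc3c2n1CC(CO)C3` differs from compound 2 by trifluoromethyl in place of bromo on an aromatic carbon. Within the data shown here, no measured step involves a trifluoromethyl group, so the only step that bears on this change is the one from compound 1 to compound 2, which itself stayed within the scatter. A step of similar size in this assay, in either direction or none beyond the scatter, is expected for compound 3, and the estimated change is a 1.4-fold lower number from compound 2 to compound 3 (0.14 log units; within the scatter). Compound 3 is expected to give 600 ug/mL, with a range from 250 ug/mL to 1400 ug/mL.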

Compound 3, solubility: 4810 ug/mL
Beside the measured number, compound 3's estimate is 8.0-fold (0.90 log units) below it, and the stated range ends below it.
By their numbers in this assay, from the lowest: compounds 1 and 2 (each within the scatter of the next); then compound 3.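

At this position, the six-membered aromatic ring of the shared core proves sensitive to the group it carries in this assay: methoxy and bromo stayed within the scatter of each other, but trifluoromethyl gives a 5.8-fold higher number from compound 2 to compound 3 (0.76 log units; beyond the scatter) and a 9.8-fold higher number from compound 1 to compound 3 (0.99 log units; beyond the scatter). Both steps lie beyond the scatter, so compound 3 stands apart from compound 1 and compound 2, and the earlier pair gave no sign of a change of this size. No measurement shown here accounts for the rise.

From the compounds shown here alone, it remains open whether the rise is particular to trifluoromethyl or would also appear with a nitrile, a carboxylic acid or an amine at this position. Going by these compounds, whether the same change on another aromatic carbon of the core would give a similar step is also open.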